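Hydroxy for methyl on the aryl ring of compound 3

This account rests on a few compounds, and the source may have more. Where it says the series, first, only, none or still open, it means among the compounds named here.

Measured compounds:
compound 1 `CCn1nnc(-c2sc(-c3cccc(OC)c3)nc2O)n1`: 245 nM
compound 2 `CCON(C)C(=O)c1sc(-c2cccc(F)c2)nc1O`: 1680 nM
compound 3 `CCn1nnc(-c2sc(-c3cccc(C)c3)nc2O)n1`: 369 nM

In an assay on HEK293 cells for inhibition of transient receptor potential cation channel subfamily M member 8 (Homo sapiens), read by FLIPR, with stated times of 5 min and 3 min (on this read-out higher numbers stand for weaker inhibition and lower numbers for stronger inhibition), compound 3 gives 369 nM, the second highest of the three numbers. Among the compounds with values here, its nearest neighbour is compound 1, within the scatter, and the only step between two compounds that differ in one place is a 1.5-fold higher number from compound 1 to compound 3 (0.18 log units; within the scatter). Compound 2 lies furthest from compound 3, beyond the scatter, but differs from it in more than one place.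

Compound 4 `CCn1nnc(-c2sc(-c3cccc(O)c3)nc2O)n1` differs from compound 3 by hydroxy in place of methyl on an aromatic carbon. Within the data shown here, no measured step on this assay exchanges a methyl for a hydroxy, so the single step at hand, which was within the scatter, gives only loose guidance. Compound 4 is therefore expected to land near compound 3, with the step of a 1.2-fold higher number from compound 3 to compound 4 (0.09 log units; within the scatter) and an estimated value of 450 nM, between 150 nM and 1400 nM.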

Compound 4, half-maximal inhibitory concentration: 239 nM
Compound 4: the middle estimate sits 1.9-fold (0.27 log units) above what was measured; measured number inside the range.
By their numbers in this assay, from the lowest: compounds 4, 1 and 3 (each within the scatter of the next); then compound 2.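

In this assay hydroxy at this aromatic carbon brings a hydrogen-bond donor and gives a 1.5-fold lower number from compound 3 to compound 4 (0.19 log units; within the scatter) against methyl, while hydrogen in place of methyl on the oxygen gives a 1.0-fold lower number from compound 1 to compound 4 (0.01 log units; within the scatter) against methoxy. Methyl, methoxy and hydroxy on this carbon thus cannot be told apart by their numbers, so here the added donor brings no change beyond the scatter. Nothing available explains this result. On these data alone, whether an amine, a carboxylic acid or a longer chain such as butoxy at this carbon would separate from these three remains open.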